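A few compounds are considered here, and "the series" means these few. Any claim that something is new, unique, unknown or untested is made for them only; others in the source may bear on it.

Working notes on the series. Compound 1 `COC(=O)c1c(Nc2ccccc2)sc(C(=O)c2ccc(OC)cc2)c1C` is the point of reference. In a functional assay, with a stated time of 150 min, tested at 5 ug/mL (a higher number here means a stronger effect of the compound at the concentration tested, a lower number a weaker effect), compound 1 gives 13.3%, the higher of the two numbers in hand. Compound 3 `COC(=O)c1c(Nc2ccccc2)sc(C(=O)c2ccc(C)cc2)c1C` gives 2.08% in this assay, and compound 2 `COC(=O)c1c(Nc2ccc(C)cc2)sc(C(=O)c2ccc(OC)cc2)c1C` is recorded in this assay as "not active" (no number reported), with no number reported. Among the measured compounds shown here, the only step between measured compounds that differ in a single place is a number 11.2 percentage points lower from compound 1 to compound 3 (beyond the scatter), a methyl in place of methoxy on an aromatic carbon.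

Compound 4 `COc1ccc(C(=O)c2sc(Nc3ccccc3)c(C(=O)O)c2C)cc1` differs from compound 1 by hydrogen in place of methyl on an oxygen next to a carbonyl group. This change turns the methoxycarbonyl of the shared core into carboxy and leaves the aromatic methoxy of compound 1 untouched, so it is not the change seen between compound 1 and compound 3. For the measured compounds named here, no measured step bears on it directly. Going by the values given here, the one step available shows that a single small change elsewhere moved the read-out by a modest amount, but it gives no direction for the present change. The expectation is therefore a modest shift from the value of compound 1, direction open, with a real chance that the read-out falls into the range where no number is reported.

Compound 4 is expected to give about 9% in this assay, within 0% to 22%. The step this implies is estimated as a number 4.3 percentage points lower from compound 1 to compound 4 (within the scatter).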

Compound 4, a percentage reported as activity, at one concentration (the size of the read-out at that concentration, not a potency): 19.6%
The estimate for compound 4 lay 10.6 percentage points below the measured number, within the range that was stated.
By their numbers in this assay, from the lowest: compound 3; then compounds 1 and 4 (each within the scatter of the next).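

At the methoxycarbonyl of the shared core, hydrogen in place of methyl on an oxygen next to a carbonyl group, which gives carboxy, produces in this assay a number 6.3 percentage points higher from compound 1 to compound 4 (within the scatter), so this step cannot be told apart from no change. Among the compounds shown here, the earlier step, a number 11.2 percentage points lower from compound 1 to compound 3 (beyond the scatter), was a methyl in place of methoxy on an aromatic carbon and lay beyond the scatter; the present one is the first reading at this position and shows that compound 4 keeps a reported number without the methyl on this oxygen. Nothing in hand explains this result.

Going by these compounds, with only methyl and hydrogen seen on this oxygen, it remains open whether an ethyl ester or a primary amide in place of the carboxy would also stay within the scatter of compound 1. It is also open whether the methyl in place of methoxy on an aromatic carbon would give a similar step with carboxy in place of methoxycarbonyl, and single-concentration read-outs in this assay give no potency for any of these compounds.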